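Acetylating the pyrrolidine amine of compound 2

A few compounds are considered here, and "the series" means these few. Any claim that something is new, unique, unknown or untested is made for them only; others in the source may bear on it.

Compound 1 `CN(c1nc2c(c(Nc3ccc(C(F)(F)F)cc3)n1)CCN(c1ncccc1C(F)(F)F)CC2)C1CCCNC1`: 1540 nM
Compound 2 `CNC1CCN(c2nc3c(c(Nc4ccc(C(F)(F)F)cc4)n2)CCN(c2ncccc2C(F)(F)F)CC3)C1`: > 5000 nM

In a functional assay on HEK293 cells for antagonist activity at transient receptor potential cation channel subfamily V member 1 (Rattus norvegicus), read by FLIPR and calcium flux (a lower number here means a stronger inhibitor, a higher number a weaker inhibitor), compound 1 gives 1540 nM. For compound 2 this assay reports only a limit, > 5000 nM. The step of an at least 3.2-fold higher number from compound 1 to compound 2 (0.51 log units; beyond the scatter) is accordingly a lower bound, which rests on (the limit of > 5000 nM in this assay, at which 1 of the 2 values shown sits). Compound 2 thus stands at the weaker end of the two values shown, with no number to place it more closely. Compound 3 `CC(=O)NC1CCN(c2nc3c(c(Nc4ccc(C(F)(F)F)cc4)n2)CCN(c2ncccc2C(F)(F)F)CC3)C1` differs from compound 2 by acetyl in place of methyl on an amine nitrogen. Among the measured compounds shown here, no measured step concerns this change; the single step, from compound 1 to compound 2, alters the ring that carries the amine and not its substituent. With compound 2 already at the limit, compound 3 is expected to sit at or beyond it as well, and the step that the limit leaves unreadable from compound 2 to compound 3 is estimated to be small. Compound 3 is therefore estimated at 9000 nM, within 3000 nM to 30000 nM.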

Compound 3, half-maximal inhibitory concentration in the transient receptor potential cation channel subfamily V member 1 assay: 410 nM
Compound 3: middle estimate off by 22-fold (1.34 log units), on the high side, outside the stated range (below it).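

In the transient receptor potential cation channel subfamily V member 1 assay, acetyl in place of methyl on the amine nitrogen gives an at least 12-fold lower number from compound 2 to compound 3 (1.08 log units; beyond the scatter), and this size is only a bound, since compound 2 stands at a limit: the limit of > 5000 nM in the transient receptor potential cation channel subfamily V member 1 assay, at which 1 of the 3 values shown sits. The change also turns the pyrrolidine from the poorer of the two amine-bearing side groups into the better one, as the transient receptor potential cation channel subfamily V member 1 assay shows a 3.8-fold lower number from compound 1 to compound 3 (0.57 log units; beyond the scatter), so the ring need not be what holds this position back. The gain comes with a loss in a physicochemical assay for solubility, in simulated intestinal fluid, measured as thermodynamic solubility, at pH 6.8 (a lower number here means a less soluble compound, a higher number a more soluble compound), where compound 2 gives 233 ug/mL and compound 3 gives 19 ug/mL: the measured solubility of compound 2, 233 ug/mL, and of compound 3, 19 ug/mL, a 12-fold lower number (1.09 log units; beyond the scatter).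

The compounds shown leave open whether the gain belongs to acetyl alone or would also hold for a longer acyl chain such as propanoyl, or for a methanesulfonyl group, on the same nitrogen. They also leave open whether acetyl on the piperidine nitrogen of compound 1 would give a similar step.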